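Hydroxyl moved on the shared core

The source may hold more compounds than are shown below. What is called first, only, known or untested is meant among the compounds shown, and "the series" means these compounds.

Compound 1 `Oc1ccccc1-c1cc(-c2ccccc2F)cc(-c2ccccc2O)n1` is known only through a limit: in a functional assay on HCT-15 cells (Homo sapiens) for inhibition (on this read-out higher numbers stand for weaker inhibition and lower numbers for stronger inhibition), compound 1 gives > 50000 nM. Compound 2 `Oc1ccccc1-c1cc(-c2ccc(F)cc2)cc(-c2ccccc2O)n1` also reaches only a limit, > 50000 nM, in this assay. The step that the two limits leave unreadable from compound 1 to compound 2 thus cannot be read; both values sit at the limit of > 50000 nM in this assay, at which 2 of the 2 values shown sit. Compound 3 `Oc1cccc(-c2cc(-c3ccccc3F)cc(-c3ccccc3O)n2)c1` differs from compound 1 by 3-hydroxyphenyl in place of 2-hydroxyphenyl on an aromatic carbon. Among the compounds with values here, no measured step bears on this change, and the single measured step is itself unreadable, so nothing argues for inhibition stronger than the limit. Compound 3 is expected at 60000 nM (range 20000 nM to 200000 nM) in this assay, the expected step that the limit leaves unreadable from compound 1 to compound 3 lying within the scatter.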

Compound 3, half-maximal inhibitory concentration: 8470 nM
Compound 3: the middle estimate sits 7.1-fold (0.85 log units) above what was measured; the measured number lies below the stated range.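

In this assay, 3-hydroxyphenyl in place of 2-hydroxyphenyl next to the ring nitrogen gives an at least 5.9-fold lower number from compound 1 to compound 3 (0.77 log units; beyond the scatter), so inhibition at this position depends on where the hydroxyl sits, though the two compounds have the same atoms. Compound 3 is the only compound shown with a number, and the full size of the step stays unknown, because compound 1 is held only at a limit: the limit of > 50000 nM in this assay, at which 2 of the 3 values shown sit.

Open, on these data alone, is whether an amine or a carboxylic acid in place of this hydroxyl would keep the inhibition. Also open, as far as these compounds go, is whether the same change carries over to the 4-fluorophenyl core of compound 2.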